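Swapping the amide ring on a weak antiproliferative compound

A few compounds are considered here, and "the series" means these few. Any claim that something is new, unique, unknown or untested is made for them only; others in the source may bear on it.

Measured so far:
Compound 1 `COc1cc(F)c(NC(=O)c2nccn2C)cc1Nc1nccc(-c2cn(C)c3ccccc23)n1` gives 5140 nM in a functional assay on A549 cells (Homo sapiens) for antiproliferative activity, read by MTT assay, with a stated time of 72 h; a higher number here means a weaker inhibitor, a lower number a stronger inhibitor.
Compound 2 `COc1cc(N(C)CCN(C)C)c(NC(=O)c2ccncc2)cc1Nc1nccc(-c2cn(C)c3ccccc23)n1` gives 10400 nM in this assay.

Of the two compounds measured, compound 2 stands at the higher, and so weaker, end, and its nearest neighbour is compound 1 with a lower number, a gap that lies beyond the usual scatter. The two compounds differ in more than one place, so their gap cannot be tied to any single change.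

Compound 3 `COc1cc(N(C)CCN(C)C)c(NC(=O)c2ncccn2)cc1Nc1nccc(-c2cn(C)c3ccccc23)n1` is the untested compound. It is built from compound 2 by a single change: pyrimidin-2-yl in place of pyridin-4-yl on a carbonyl carbon. The rest of the molecule, including the shared core and the side chain, stays as it is.

Within the data shown here, no measured pair shows this exact swap, so there is no direct guide to its effect. The expected step is therefore small: in this assay the change from compound 2 to compound 3 is estimated at a 1.3-fold lower number from compound 2 to compound 3 (0.11 log units; within the scatter), which is within the scatter. Compound 3 is expected to give about 8000 nM in this assay, with a likely range from 2500 nM to 25000 nM.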

Compound 3, half-maximal inhibitory concentration: 2490 nM
Estimate against measurement, compound 3: 3.2-fold (0.51 log units) above; the whole stated range lies above it.
By their numbers in this assay, from the lowest: compound 3; then compound 1; then compound 2.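

Among these compounds, this is the first comparison that isolates one change, and it shows that the ring on the amide carbonyl is not a passive part of the molecule: in this assay pyrimidin-2-yl in place of pyridin-4-yl on a carbonyl carbon gives a 4.2-fold lower number from compound 2 to compound 3 (0.62 log units; beyond the scatter) and the shared core and side chain stay untouched. The size of the ring does not change, since both groups have the same count of heavy atoms, so the step comes with a ring carbon traded for a nitrogen, one more hydrogen-bond acceptor and a different point of attachment to the ring. Nothing shown here measures why this swap helps.

This single pair cannot separate the effect of the second ring nitrogen from that of where the ring nitrogens sit, and a comparison with pyridin-2-yl or a plain phenyl ring on the same carbonyl would bear on that question. It also leaves open whether pyrimidin-2-yl would bring a similar step on a molecule that carries another side chain, such as a morpholine or a piperazine.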